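The compounds below may be only part of what the source reports. "The series", "measured", "known", "first", "only" and "open" are said of these compounds alone.

Measured compounds:
- compound 1, `COc1cc(-c2cc(/C=C/C(=O)c3ccc(N)cc3)[nH]n2)cc(OC)c1OC`: 10500 nM
- compound 2, `COc1ccc(-c2cc(/C=C/C(=O)c3ccc(N)cc3)[nH]n2)cc1OC`: 19000 nM

Both compounds were tested in a functional assay on IGROV-1 cells (Homo sapiens) for inhibition, read by sulforhodamine B assay, with a stated time of 48 h; on this read-out lower numbers stand for stronger inhibition of growth and higher numbers for weaker inhibition of growth. Among the measured compounds shown here, compound 1 holds the lowest of the two numbers; its nearest neighbour is compound 2, and the only step between them, a 1.8-fold higher number from compound 1 to compound 2 (0.26 log units; within the scatter), stays within the scatter, so the two cannot be told apart on these numbers.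

Compound 3, `COc1ccc(C(=O)/C=C/c2cc(-c3cc(OC)c(OC)c(OC)c3)n[nH]2)cc1`, has not yet been measured. It differs from compound 1 in one place: methoxy in place of amino on an aromatic carbon, on an aromatic carbon of a six-membered aromatic ring of carbon only, para to a large group. For the measured compounds named here, no measured step covers this change; the one step on record, from compound 1 to compound 2, alters a methoxy on a different part of the shared core and was itself within the scatter. With nothing pointing either way, he expects the step of a 1.1-fold higher number from compound 1 to compound 3 (0.06 log units; within the scatter) to stay within the scatter. His estimate for compound 3 is therefore 12000 nM, with a range from 4000 nM to 35000 nM.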

Compound 3, concentration for total growth inhibition: 4810 nM
Beside the measured number, compound 3's estimate is 2.5-fold (0.40 log units) above it; the range from low to high includes it.
By their numbers in this assay, from the lowest: compound 3; then compounds 1 and 2 (each within the scatter of the next).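

In this assay, among the compounds shown here, the replacement of 4-aminophenyl by 4-methoxyphenyl gives a 2.2-fold lower number from compound 1 to compound 3 (0.34 log units; beyond the scatter) and is the first step in this set to lie beyond the scatter, although it is modest. For the compounds shown here, the earlier pair changed a different part of the shared core, so this is the first sign that the number responds to a change on an aromatic carbon of a six-membered aromatic ring of carbon only, para to a large group, and it also shows that the amino group is not required for growth inhibition at this level. No independent evidence is available to explain the size or direction of this step.

With only one replacement at this position, the compounds shown cannot separate a contribution from the entering methoxy from one tied to the departing amino, and a hydroxyl, a chlorine or a dimethylamino group there would help to distinguish the two. They also leave open whether the same replacement would produce a similar step on the core of compound 2.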